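Pyrazoline sulfonamides: aryl replaces styryl at the saturated carbon

A few compounds are considered here, and "the series" means these few. Any claim that something is new, unique, unknown or untested is made for them only; others in the source may bear on it.

In a functional assay on BT-549 cells (Homo sapiens) for antiproliferative activity, with a stated time of 48 h (a higher number here means a weaker inhibitor of growth, a lower number a stronger inhibitor of growth), compound 1 `Cc1cc(O)c(C2=NN(c3ccc(S(N)(=O)=O)cc3)C(c3ccccc3Cl)C2)cc1Cl` gives 4740 nM. Compound 2 `Cc1cc(O)c(C2=NN(c3ccc(S(N)(=O)=O)cc3)C(/C=C/c3ccccc3)C2)cc1Cl` gives 21300 nM in this assay, the highest of the two numbers shown; its nearest neighbour is compound 1, and the one measured step, a 4.5-fold higher number from compound 1 to compound 2 (0.65 log units; beyond the scatter), separates them and lies beyond the scatter. Compound 3 `COc1ccc(C2CC(c3cc(Cl)c(C)cc3O)=NN2c2ccc(S(N)(=O)=O)cc2)cc1OC` is not yet measured. It differs from compound 2 in one place: 3,4-dimethoxyphenyl in place of 2-phenylethenyl on a saturated ring carbon. Going by the values given here, the only step that bears on this change is the one from compound 1 to compound 2, where an aromatic ring at that saturated ring carbon gave way to 2-phenylethenyl and the number rose by a 4.5-fold higher number from compound 1 to compound 2 (0.65 log units; beyond the scatter). Compound 3 returns an aromatic ring to the same carbon, though a different one from that in compound 1, so the step is expected to run the other way, with a lower number in this assay and a size near that of the measured step. For compound 3 the estimate is 6000 nM with a range of 2500 nM to 15000 nM, which is expected to mean a 3.6-fold lower number from compound 2 to compound 3 (0.55 log units; beyond the scatter).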

Compound 3, concentration for total growth inhibition: 13400 nM
For compound 3 the middle estimate is 2.2-fold (0.35 log units) below the measured one; measured number inside the range.
By their numbers in this assay, from the lowest: compound 1; then compounds 3 and 2 (each within the scatter of the next).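

In this assay, the second aromatic ring at this saturated ring carbon does not repeat what the first one did: 3,4-dimethoxyphenyl in place of 2-phenylethenyl gives a 1.6-fold lower number from compound 2 to compound 3 (0.20 log units; within the scatter), so these two groups cannot be told apart here, and compound 3 goes against any reading of the earlier step as a general preference for an aromatic ring over 2-phenylethenyl. The change between the two aromatic groups does register, with 3,4-dimethoxyphenyl in place of 2-chlorophenyl giving a 2.8-fold higher number from compound 1 to compound 3 (0.45 log units; beyond the scatter), which ties the lower number of compound 1 to 2-chlorophenyl in particular rather than to the presence of any six-membered aromatic ring at this carbon. Nothing available bears on the reason for this difference.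

The compounds shown leave open whether the lower number of compound 1 goes with the chlorine itself or needs the ring that carries it, and whether both methoxy groups of compound 3 take part in its higher number. An unsubstituted phenyl, a methoxyphenyl with a single methoxy group or a saturated cyclohexyl at this carbon would each bear on those questions.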